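Notes on amine-bearing ether side chains in the series

The source may hold more compounds than are shown below. What is called first, only, known or untested is meant among the compounds shown, and "the series" means these compounds.

Measured so far, in a functional assay on PC-3 cells (Homo sapiens) for antiproliferative activity, read by WST assay, with a stated time of 3 days; a lower number here means a stronger inhibitor, a higher number a weaker inhibitor:
compound 1 `CCCCCCOc1c(-c2cc(OC)c(OC)c(OC)c2)oc2ccccc2c1=O` — 29200 nM.
compound 2 `CCCCCCCOc1c(-c2cc(OC)c(OC)c(OC)c2)oc2ccccc2c1=O` — > 50000 nM.
compound 3 `CCCN(CCC)CCCOc1c(-c2cc(OC)c(OC)c(OC)c2)oc2ccccc2c1=O` — 16800 nM.

The value of compound 2 is a limit of the assay and not a number. Compound 2 thus stands at the limit of > 50000 nM in this assay, at which 1 of the 3 values shown sits, the only one of the three without a numerical value in this assay. The step from compound 1 to compound 2 reads an at least 1.7-fold higher number from compound 1 to compound 2 (0.23 log units; that floor lies within the scatter). From compound 1 to compound 3 the step is a 1.7-fold lower number from compound 1 to compound 3 (0.24 log units; within the scatter). The step that matters most here, from compound 2 to compound 3, is an at least 2.9-fold lower number from compound 2 to compound 3 (0.47 log units; beyond the scatter).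

Compound 4 `CCCCCN(CCCCC)CCCOc1c(-c2cc(OC)c(OC)c(OC)c2)oc2ccccc2c1=O` is still to be measured. Its difference from compound 2 is dipentylamino in place of butyl on a saturated chain carbon, three bonds along the chain from an oxygen on an aromatic ring. The step from compound 2 to compound 3 concerns the same place and the same leaving group, and ran toward a lower number; compound 4 carries the longer dipentylamino instead. The step from compound 1 to compound 2, a lengthening of the chain, ran toward a higher number but lay within the scatter. A lower number than the limit of compound 2 is therefore expected for compound 4, of at least the size seen from compound 2 to compound 3, with some chance that the assay again reports only a limit. The estimated step is an at least 2.2-fold lower number from compound 2 to compound 4 (0.35 log units; beyond the scatter). The estimate for compound 4 in this assay is 22000 nM, between 7000 nM and 60000 nM.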

Compound 4, half-maximal inhibitory concentration: 5800 nM
For compound 4 the middle estimate is 3.8-fold (0.58 log units) above the measured one; measured number below the stated range.
By their numbers in this assay, from the lowest: compound 4; then compounds 3 and 1 (each within the scatter of the next). At a limit, above all of these: compound 2.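

Notes on the result: in this assay the first amine gave no clear separation from the simple alkyl ether (a 1.7-fold lower number from compound 1 to compound 3 (0.24 log units; within the scatter)), whereas the dipentylamino group at the same place does (a 5.0-fold lower number from compound 1 to compound 4 (0.70 log units; beyond the scatter)). The two amines also differ from each other, so at this place, on a saturated chain carbon three bonds along the chain from an oxygen on an aromatic ring, the alkyl groups on the nitrogen matter and not only the presence of the amine (a 2.9-fold lower number from compound 3 to compound 4 (0.46 log units; beyond the scatter)). The comparison with the plain alkyl chain of compound 2 gives only a floor (an at least 8.6-fold lower number from compound 2 to compound 4 (0.93 log units; beyond the scatter)), as compound 2 has a limit and not a number: the limit of > 50000 nM in this assay, at which 1 of the 4 values shown sits.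

As far as these compounds go, two amines fix no trend, so it remains open whether the change continues with a dihexylamino group or falls away, and whether a cyclic amine such as piperidine or morpholine would serve in place of the open dialkylamino groups. Also open, from the compounds shown here alone, is how a shorter or longer chain between the ether oxygen and the nitrogen would act with dipentylamino held constant.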